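This account rests on a few compounds, and the source may have more. Where it says the series, first, only, none or still open, it means among the compounds named here.

Compound 1 `COc1cccc(-c2ccc([C@H]3S[C@@H](C)C(=O)Nc4c3c(C)nn4-c3ccccc3C)cc2)c1` gives 1800 nM in an assay on isolated protein for agonist activity at Bile acid receptor (Homo sapiens), read by AlphaScreen, with a stated time of 30 min; a lower number here means that less compound is needed, a higher number that more compound is needed for the effect.
Compound 2 `Cc1ccccc1-n1nc(C)c2c1NC(=O)[C@H](C)S[C@@H]2c1ccc(-c2ccsc2)cc1` gives 1400 nM in this assay.

Compound 2 and compound 1 lie within the scatter of each other, so neither can be called the stronger. Compound 3 `COc1ccc(Oc2ccc([C@H]3S[C@@H](C)C(=O)Nc4c3c(C)nn4-c3ccccc3C)cc2)cc1` takes the next step: 4-methoxyphenoxy in place of thiophen-3-yl on an aromatic carbon. Among the measured compounds shown here, the only measured step, a 1.3-fold lower number from compound 1 to compound 2 (0.11 log units; within the scatter), exchanged one ring for another at that aromatic carbon without a shift beyond the scatter. For the measured compounds named here, no measured step involves a phenoxy group. The expectation in this assay is therefore a step of a 1.1-fold higher number from compound 2 to compound 3 (0.03 log units; within the scatter), nothing clearly beyond the scatter. Compound 3 is estimated at 1500 nM, within 500 nM to 4500 nM.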

Compound 3, half-maximal effective concentration: 2200 nM
Compound 3: the middle estimate sits 1.5-fold (0.17 log units) below what was measured; measured number inside the range.
By their numbers in this assay, from the lowest: compounds 2, 1 and 3 (each within the scatter of the next).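

In this assay this aromatic carbon also tolerates 4-methoxyphenoxy, a group joined through oxygen and larger than thiophen-3-yl, with 9 heavy atoms against 5. Putting it in place of thiophen-3-yl (a 1.6-fold higher number from compound 2 to compound 3 (0.20 log units; within the scatter)) or of 3-methoxyphenyl (a 1.2-fold higher number from compound 1 to compound 3 (0.09 log units; within the scatter)) moves the number no further than the scatter, so all three ring groups read alike here. Nothing measured explains why the number stays so flat.

From the compounds shown here alone, whether an amine or a carboxylic acid on this carbon would shift the number beyond the scatter remains open. So does whether any change here can bring it clearly lower.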